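Urea-linked analogues in a cell growth assay

A few compounds are considered here, and "the series" means these few. Any claim that something is new, unique, unknown or untested is made for them only; others in the source may bear on it.

Measured compounds:
compound 1 `CCOc1ccc(NC(=O)Nc2cccc(CNc3nccnc3Cl)c2)cc1`, 7050 nM
compound 2 `O=C(Nc1ccccc1)Nc1cccc(CNc2nccnc2Cl)c1`, 15600 nM
compound 3 `Cc1cccc(NC(=O)Nc2cccc(CNc3nccnc3Cl)c2)c1`, 11200 nM

In a functional assay on HepG2 cells (Homo sapiens) for antiproliferative activity, read by MTT assay, with a stated time of 48 h (on this read-out higher numbers stand for weaker inhibition and lower numbers for stronger inhibition), compound 1 gives 7050 nM, the lowest of the three numbers. The step of a 2.2-fold higher number from compound 1 to compound 2 (0.34 log units; beyond the scatter) removes the ethoxy group and is the only one beyond the scatter, while a 1.6-fold higher number from compound 1 to compound 3 (0.20 log units; within the scatter) and a 1.4-fold lower number from compound 2 to compound 3 (0.14 log units; within the scatter) both stay within it. Compound 4 `CCc1ccccc1NC(=O)Nc1cccc(CNc2nccnc2Cl)c1` has not yet been measured. It differs from compound 1 by 2-ethylphenyl in place of 4-ethoxyphenyl on an amide-type nitrogen. Both earlier departures from the 4-ethoxyphenyl group of compound 1 gave higher numbers, so a modest rise in this assay is expected for compound 4, of about a 1.5-fold higher number from compound 1 to compound 4 (0.17 log units; within the scatter). The estimate for compound 4 is therefore 10500 nM, expected to lie between 5000 nM and 22000 nM.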

Compound 4, half-maximal inhibitory concentration: 7860 nM
Compound 4: the middle estimate sits 1.3-fold (0.13 log units) above what was measured, within the range that was stated.
By their numbers in this assay, from the lowest: compounds 1, 4, 3 and 2 (each within the scatter of the next, the first and the last beyond it).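

In this assay the 2-ethylphenyl group on the amide-type nitrogen stays level with the 4-ethoxyphenyl group (a 1.1-fold higher number from compound 1 to compound 4 (0.05 log units; within the scatter)), so at this position a group without oxygen can read the same as compound 1. The other two steps also stay within the scatter (a 1.4-fold lower number from compound 3 to compound 4 (0.15 log units; within the scatter); a 2.0-fold lower number from compound 2 to compound 4 (0.30 log units; within the scatter)), whereas the step from compound 1 to compound 2 went beyond it. Nothing available explains why these groups read alike. On these data alone, what a dimethylamino group, a carboxylic acid or a butoxy chain on this aromatic ring would give in this assay stays open.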